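A few compounds are considered here, and "the series" means these few. Any claim that something is new, unique, unknown or untested is made for them only; others in the source may bear on it.

Measured compounds:
compound 1 `FC(F)(F)c1ccc(Nc2ncnc3sc(Nc4c(Cl)cccc4Cl)nc23)cc1`: 12 nM in a functional assay on HEK293 cells for antagonist activity at transient receptor potential cation channel subfamily V member 1 (Homo sapiens), read by calcium flux; a higher number here means a weaker inhibitor, a lower number a stronger inhibitor
compound 2 `CS(=O)(=O)c1ccc(Nc2ncnc3sc(Nc4c(Cl)cccc4Cl)nc23)cc1`: 5 nM in this assay
compound 3 `FC(F)(F)c1ccc(Nc2nc(N3CCNCC3)nc3sc(Nc4c(Cl)cccc4Cl)nc23)cc1`: 5000 nM in this assay

Compound 1 stands second highest of the three numbers. The nearest neighbour is reached by a 2.4-fold lower number from compound 1 to compound 2 (0.38 log units; beyond the scatter); the furthest by a 420-fold higher number from compound 1 to compound 3 (2.62 log units; beyond the scatter).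

Compound 4 `COC(=O)c1cc(Cl)c(Nc2nc3c(Nc4ccc(C(F)(F)F)cc4)ncnc3s2)c(Cl)c1` has not yet been measured. It differs from compound 1 by methoxycarbonyl in place of hydrogen on an aromatic carbon; the new group sits meta to two chloro groups and para to a large group.

Neither measured step touches that ring. The step of a 2.4-fold lower number from compound 1 to compound 2 (0.38 log units; beyond the scatter) exchanges a substituent on the other aryl ring and is modest; the step of a 420-fold higher number from compound 1 to compound 3 (2.62 log units; beyond the scatter) adds a substituent on the shared core and is large. Among the measured compounds shown here, both changes lie elsewhere, so no measured step bears directly on the change to compound 4. For the measured compounds named here, the one aryl-substituent exchange seen so far was small; the one large effect came from the core, not from an aryl ring. On that slender basis a step of modest size is expected, with the direction uncertain and a mild rise in the number somewhat more likely than a fall, as a 2.1-fold higher number from compound 1 to compound 4 (0.32 log units; beyond the scatter).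

Compound 4 is therefore estimated at 25 nM, within 5 nM to 150 nM.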

Compound 4, half-maximal inhibitory concentration: 820 nM
Compound 4: the middle estimate sits 33-fold (1.52 log units) below what was measured, outside the stated range (above it).
By their numbers in this assay, from the lowest: compound 2; then compound 1; then compound 4; then compound 3.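

In this assay, the carbon meta to the two chloro groups on the shared dichlorophenyl-bearing ring proves sensitive to substitution: methoxycarbonyl in place of hydrogen gives a 68-fold higher number from compound 1 to compound 4 (1.83 log units; beyond the scatter) and turns compound 1 into a much weaker inhibitor. Among the compounds shown here, until now the only large step lay on the shared core, a 420-fold higher number from compound 1 to compound 3 (2.62 log units; beyond the scatter) while the exchange on the other aryl ring stayed modest, a 2.4-fold lower number from compound 1 to compound 2 (0.38 log units; beyond the scatter) so large steps are no longer confined to the core and a single aryl substitution can also produce one. Nothing shown explains why this group at this carbon costs so much.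

For the compounds shown here, with methoxycarbonyl the only group at this carbon, the series cannot yet separate an effect of this particular ester from an effect of any substituent placed there; a carboxylic acid, a primary amide, a methyl or a single fluorine at the same carbon would draw that line. On these data alone, it also remains open whether the same step would appear on the methylsulfonyl-bearing scaffold of compound 2, where the other aryl ring differs.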